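From phenyl to 4-chlorophenyl: compound 2 to compound 3

The compounds below may be only part of what the source reports. "The series", "measured", "known", "first", "only" and "open" are said of these compounds alone.

Compound 1 `COc1ccc2c(c1)c(C1CC(c3ccccc3)=NN1C(=O)c1cccnc1)cn2C` and compound 2 `COc1ccc2c(c1)c(C1CC(c3ccccc3)=NN1C(=O)c1ccc(OC)nc1)cn2C` share a core, and both were measured in an ADME assay on HEK-293T cells (Homo sapiens) for cytotoxicity, read by MTT assay, with a stated time of 48 h; a lower number here means that less compound is tolerated, a higher number that more compound is tolerated. Compound 1 gives > 300000 nM, which is a limit and not a number. Compound 2 gives > 300000 nM, also a limit. Compound 2 therefore has no numerical position in the series, and the evidence so far is the limit of > 300000 nM in this assay, at which 2 of the 2 values shown sit.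

Compound 3 `COc1ccc2c(c1)c(C1CC(c3ccc(Cl)cc3)=NN1C(=O)c1ccc(OC)nc1)cn2C` differs from compound 2 by chloro in place of hydrogen on an aromatic carbon. In words, this is chloro in place of hydrogen on an aromatic carbon, or phenyl to 4-chlorophenyl.

Within the data shown here, the only measured step is a step that the two limits leave unreadable from compound 1 to compound 2. It concerns methoxy rather than chloro and gives no size to carry over. Among the measured compounds shown here, no measured step covers the chloro change, so the working expectation in this assay is no step beyond the scatter, with no direction favoured by the data. The estimated step is a number no higher from compound 2 to compound 3 (the limit leaves the size open). The estimated value for compound 3 is 300000 nM, with an expected range of 120000 nM to 600000 nM.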

Compound 3, half-maximal cytotoxic concentration: > 300000 nM
Compound 3 ended at the assay's limit; the forecaster's own chance of this, stated with the estimate: 75%; the middle value sits exactly at the limit.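

Compound 2 and compound 3 both stand at a limit in this assay, not at a number, so no step can be read between them and the chloro change gets no size. The compounds shown leave open where the half-maximal cytotoxic concentration of each one lies, and whether methoxy or chloro shifts it at all: the limit of > 300000 nM in this assay, at which 3 of the 3 values shown sit.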